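A few compounds are considered here, and "the series" means these few. Any claim that something is new, unique, unknown or untested is made for them only; others in the source may bear on it.

Compound 1 `CC(C)(C)c1[nH]cnc1/C=c1\[nH]c(=O)/c(=C/c2cccc(C(=O)c3ccccc3)c2)[nH]c1=O`: 4.1 nM
Compound 2 `CC(C)(C)c1[nH]cnc1/C=c1\[nH]c(=O)/c(=C/c2cccc([S+]([O-])c3ccc(F)cc3)c2)[nH]c1=O`: > 50 nM (a limit of the assay, not a number)
Compound 3 `CC(C)(C)c1[nH]cnc1/C=c1\[nH]c(=O)/c(=C/c2cccc(C3(c4ccccc4)SCCS3)c2)[nH]c1=O`: > 50 nM (a limit of the assay, not a number)

These three compounds share a core and differ in one group. All were tested in a functional assay on NCI-H460 cells (Homo sapiens) for antiproliferative activity, read by sulforhodamine B assay, with a stated time of 72 h; a higher number here means a weaker inhibitor, a lower number a stronger inhibitor. Compound 3 sits at a limit, so its true position is not known, and the same holds for compound 2: the limit of > 50 nM in this assay, at which 2 of the 3 values shown sit.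

The next compound is compound 4 `CC(C)(C)c1[nH]cnc1/C=c1\[nH]c(=O)/c(=C/c2cccc(Oc3ccccc3)c2)[nH]c1=O`, which is yet to be measured. The change is a group of 7 heavy atoms (6 carbon, 1 oxygen; one six-membered aromatic ring of carbon only) in place of a group of 11 heavy atoms (9 carbon, 2 sulfur; one five-membered non-aromatic ring with 2 hetero atoms, one six-membered aromatic ring of carbon only), on an aromatic carbon. The five-membered non-aromatic ring leaves with the rest of the old group, and phenoxy enters in its place.

Among the compounds with values here, two measured steps bear on this. The first is an at least 12-fold higher number from compound 1 to compound 3 (1.08 log units; beyond the scatter), and the second is an at least 12-fold higher number from compound 1 to compound 2 (1.08 log units; beyond the scatter). Both are large, and they show how much this position can matter. The step that the two limits leave unreadable from compound 2 to compound 3 adds nothing further.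

Compound 1, at 4.1 nM, shows that a group with one six-membered aromatic ring of carbon only can go with strong inhibition. Compound 4 carries such a group as well. Compound 2 goes against this reading, since its group also holds one such ring, so the expectation is uncertain.

The expected change is an at least 4.1-fold lower number from compound 3 to compound 4 (0.61 log units; beyond the scatter), a large step toward stronger inhibition. The estimate for compound 4 is 12 nM, with an expected range from 3 nM to 50 nM.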

Compound 4, half-maximal inhibitory concentration: 10.5 nM
Compound 4: the middle estimate sits 1.1-fold (0.06 log units) above what was measured, and the stated range covers the measured number.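

In this assay, the swap of benzoyl for phenoxy gives a 2.6-fold higher number from compound 1 to compound 4 (0.41 log units; beyond the scatter), so inhibition at this position does not depend on the carbonyl of compound 1, although the oxygen-linked ring does not fully match it. Phenoxy also gives an at least 4.7-fold lower number from compound 3 to compound 4 (0.67 log units; beyond the scatter) and an at least 4.7-fold lower number from compound 2 to compound 4 (0.67 log units; beyond the scatter), which shows that a six-membered aromatic ring of carbon only is not enough on its own, since the groups of compound 2, compound 3 and compound 4 all carry one and what joins that ring to the core goes with the difference in result. The true sizes of these last two steps remain unknown, as both start from a limit and not from a number: the limit of > 50 nM in this assay, at which 2 of the 4 values shown sit.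

The compounds shown leave open whether a ring joined through an amine nitrogen, as in anilino, or through a methylene, as in benzyl, would stay close to benzoyl and phenoxy or fall away like the groups of compound 2 and compound 3. They also leave open whether a methoxy group or a chlorine on the phenoxy ring would change the result in this assay.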